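Expecting little change from compound 3 to compound 4

A few compounds are considered here, and "the series" means these few. Any claim that something is new, unique, unknown or untested is made for them only; others in the source may bear on it.

In a functional assay on HCT-116 cells (Homo sapiens) for antiproliferative activity, read by radiometric assay, with a stated time of 72 h (a higher number here means a weaker inhibitor, a lower number a stronger inhibitor), compound 1 `Cc1ccccc1Nc1ncnc2cc(NC(=O)CCCCCCC(=O)NO)sc12` gives 2560 nM, compound 2 `Cc1cc(F)ccc1Nc1ncnc2cc(NC(=O)CCCCCCC(=O)NO)sc12` gives 2640 nM and compound 3 `Cc1ccc(F)c(Nc2ncnc3cc(NC(=O)CCCCCCC(=O)NO)sc23)c1` gives 1330 nM. These numbers cannot really be told apart. The step of a 1.0-fold higher number from compound 1 to compound 2 (0.01 log units; within the scatter) lies within the scatter, and so do a 1.9-fold lower number from compound 1 to compound 3 (0.28 log units; within the scatter) and a 2.0-fold lower number from compound 2 to compound 3 (0.30 log units; within the scatter). Compound 3 therefore stands level with the other two.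

Compound 4 `COc1ccc(Nc2ncnc3cc(NC(=O)CCCCCCC(=O)NO)sc23)c(C)c1` carries 4-methoxy-2-methylphenyl in place of 2-fluoro-5-methylphenyl on a nitrogen on an aromatic ring. Going by the values given here, no measured compound holds this methoxy group, so the data offer no direct guide to it. The nearest comparison is compound 2, whose 4-fluoro-2-methylphenyl group has the same name pattern and which gives 2640 nM. Swapping that group for the one in compound 3 moved the number only slightly, as a 2.0-fold lower number from compound 2 to compound 3 (0.30 log units; within the scatter) shows, so no step beyond the scatter is expected here. The expected step is a 1.5-fold higher number from compound 3 to compound 4 (0.18 log units; within the scatter). For compound 4 the estimated value in this assay is 2000 nM, with an expected range from 900 nM to 4500 nM.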

Compound 4, half-maximal inhibitory concentration: 2480 nM
The estimate for compound 4 lay 1.2-fold (0.09 log units) below the measured number; the range from low to high includes it.
By their numbers in this assay, from the lowest: compounds 3, 4, 1 and 2 (each within the scatter of the next).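

In this assay the group on the nitrogen now holds a methoxy, the first oxygen at this place among these compounds, yet the number does not move beyond the scatter: the steps are (a 1.9-fold higher number from compound 3 to compound 4 (0.27 log units; within the scatter)) and (a 1.1-fold lower number from compound 2 to compound 4 (0.03 log units; within the scatter)) and (a 1.0-fold lower number from compound 1 to compound 4 (0.01 log units; within the scatter)). Across these four compounds, then, methoxy in place of fluoro or of hydrogen on an aromatic carbon of this ring makes no measurable difference. Nothing available explains this flat result.

Going by these compounds, what stays open is whether the flatness holds for very different groups on this ring, such as an amine, a carboxylic acid or a longer ether chain. On these data alone, all four compounds also share the same chain ending in the hydroxamic acid, so how changes there would compare remains unknown.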